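The source may report more compounds than this note shows. Statements on the series, on what has been measured and on what is new or still open speak of the compounds shown alone.

Measured in a functional assay on EC9706 cells (Homo sapiens) for antiproliferative activity, read by MTT assay, with a stated time of 48 h; on this read-out lower numbers stand for stronger inhibition and higher numbers for weaker inhibition:
- Compound 1 `CCCCCCCn1cc(COC[C@@H]2OC[C@H](N)[C@H]2O)nn1`: > 128000 nM, a limit
- Compound 2 `CCCCCCCCn1cc(COC[C@@H]2OC[C@H](N)[C@H]2O)nn1`: > 128000 nM, a limit
- Compound 3 `CCCCCCCCCCCCCCn1cc(COC[C@@H]2OC[C@H](N)[C@H]2O)nn1`: 6680 nM

For the measured compounds named here, compound 3 is the only compound with an actual number. The other two stand at the limit of > 128000 nM in this assay, at which 2 of the 3 values shown sit.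

Compound 4 `CCCCCCCCCCCCCCCCn1cc(COC[C@@H]2OC[C@H](N)[C@H]2O)nn1` puts ethyl in place of hydrogen on a saturated chain carbon, ten or more bonds along the chain from an aromatic nitrogen. Going by the values given here, two measured steps bear on this change: the large at least 19-fold lower number from compound 1 to compound 3 (1.28 log units; beyond the scatter) and the large at least 19-fold lower number from compound 2 to compound 3 (1.28 log units; beyond the scatter). Both added longer groups, heptyl and hexyl, whereas a step that the two limits leave unreadable from compound 1 to compound 2 tells nothing. With only ethyl entering, a much smaller move toward lower numbers is expected, probably within the scatter, and the estimated step is a 1.7-fold lower number from compound 3 to compound 4 (0.22 log units; within the scatter). Compound 4 is expected at 4000 nM, with an estimated range of 1500 nM to 15000 nM.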

Compound 4, half-maximal inhibitory concentration: 6310 nM
Beside the measured number, compound 4's estimate is 1.6-fold (0.20 log units) below it; measured number inside the range.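

In this assay, ethyl in place of hydrogen on a saturated chain carbon, ten or more bonds along the chain from an aromatic nitrogen, gives a 1.1-fold lower number from compound 3 to compound 4 (0.02 log units; within the scatter), so further lengthening at this place leaves the read-out level within the scatter. The large steps from the short chains persist, with an at least 20-fold lower number from compound 2 to compound 4 (1.30 log units; beyond the scatter) and an at least 20-fold lower number from compound 1 to compound 4 (1.30 log units; beyond the scatter). Compound 1 and compound 2 still stand at a limit rather than a number: the limit of > 128000 nM in this assay, at which 2 of the 4 values shown sit.

From the compounds shown here alone, what a decyl or dodecyl chain would give remains open, so the length at which measurable inhibition begins is unknown. Also open, going by these compounds, is whether an octadecyl chain would stay level or whether a terminal carboxylic acid would be tolerated.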